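From propyl to 3-methoxyphenyl on the aromatic nitrogen

The compounds below may be only part of what the source reports. "The series", "measured", "known", "first", "only" and "open" are said of these compounds alone.

Measured so far in a functional assay on MDA-MB-468 cells (Homo sapiens) for antiproliferative activity, read by MTT assay, with a stated time of 72 h; a lower number here means a stronger inhibitor, a higher number a weaker inhibitor:
- compound 1 `CCCn1ccnc1-c1cc(OC)c(OC)c(OC)c1`: > 100000 nM
- compound 2 `COc1cc(-c2nccn2-c2ccc3cc[nH]c3c2)cc(OC)c1OC`: 1700 nM

Compound 1 stands at > 100000 nM, which is a limit of the assay and not a number. The series therefore has no measured potency for compound 1, only this: the limit of > 100000 nM in this assay, at which 1 of the 2 values shown sits. Compound 2, which has no propyl, gives a number, 1700 nM. Compound 3 `COc1cccc(-n2ccnc2-c2cc(OC)c(OC)c(OC)c2)c1` keeps the core of compound 1 and carries 3-methoxyphenyl in place of propyl on an aromatic nitrogen. Among the measured compounds shown here, no measured step between compounds is available to guide this change, so the expectation rests on the value of compound 2 at 1700 nM. In this assay a large step towards stronger inhibition is expected: an at least 12-fold lower number from compound 1 to compound 3 (1.09 log units; beyond the scatter). Compound 3 is estimated at 8000 nM, with an expected range from 800 nM to 80000 nM.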

Compound 3, half-maximal inhibitory concentration: 10400 nM
Beside the measured number, compound 3's estimate is 1.3-fold (0.11 log units) below it, and the stated range covers the measured number.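

In this assay, the aromatic nitrogen of the shared core is a position where a single change moves the series from a limit of the assay to a measured number: 3-methoxyphenyl in place of propyl gives an at least 9.6-fold lower number from compound 1 to compound 3 (0.98 log units; beyond the scatter). Among the compounds shown here, this is the first readable step at this position, and it shows that a large aromatic group on this nitrogen is compatible with measurable antiproliferative activity. The step has only a lower bound, and its full size stays open, with compound 1 held at a limit of the assay: the limit of > 100000 nM in this assay, at which 1 of the 3 values shown sits.

On these data alone, whether the gain belongs to the six-membered aromatic ring itself or to its methoxy group stays open, as does what a plain phenyl, a benzyl or a longer chain would give on this nitrogen. As far as these compounds go, how an amine or a carboxylic acid on that ring would move the number is equally open.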